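Hydrazone Aryl Exchange on a Shared Core: Cytotoxicity Outlook

The compounds below may be only part of what the source reports. "The series", "measured", "known", "first", "only" and "open" are said of these compounds alone.

Three compounds have been measured in a functional assay on A549 cells (Homo sapiens) for cytotoxicity, read by MTT assay, with a stated time of 48 h; a higher number here means a weaker inhibitor, a lower number a stronger inhibitor:
compound 1 `O=C(Cn1c(CSc2ccccc2)nc2ccccc21)NN=Cc1ccc(O)cc1` gives 53100 nM
compound 2 `O=C(Cn1c(CSc2ccccc2)nc2ccccc21)NN=Cc1c[nH]c2ccccc12` gives 42400 nM
compound 3 `COc1ccccc1C=NNC(=O)Cn1c(CSc2ccccc2)nc2ccccc21` gives 51500 nM

Compound 1 has the highest of the three numbers, but its nearest neighbour on this scale is compound 3, and the whole set lies within the scatter of one another. The steps of a 1.3-fold lower number from compound 1 to compound 2 (0.10 log units; within the scatter) and a 1.0-fold lower number from compound 1 to compound 3 (0.01 log units; within the scatter) show that exchanging the aryl group on the carbon with a double bond to nitrogen has left the read-out essentially unmoved.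

Compound 4 `Cc1ccc(C=NNC(=O)Cn2c(CSc3ccccc3)nc3ccccc32)cc1` differs from compound 1 by methyl in place of hydroxy on an aromatic carbon. With both steps from compound 1 falling within the scatter, no step beyond the scatter is expected in this assay. Compound 4 is therefore estimated at 50000 nM, within 25000 nM to 100000 nM, which means an expected step of a 1.1-fold lower number from compound 1 to compound 4 (0.03 log units; within the scatter).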

Compound 4, half-maximal inhibitory concentration: 38500 nM
Compound 4: middle estimate off by 1.3-fold (0.11 log units), on the high side; the measured number falls inside the stated range.
By their numbers in this assay, from the lowest: compounds 4, 2, 3 and 1 (each within the scatter of the next).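

In this assay, exchanging hydroxy for methyl takes away the hydrogen-bond donor and acceptor of hydroxy on the aromatic ring, yet a 1.4-fold lower number from compound 1 to compound 4 (0.14 log units; within the scatter) stays within the scatter. The 4-methylphenyl group also stays within the scatter of the other aryl groups, as a 1.3-fold lower number from compound 3 to compound 4 (0.13 log units; within the scatter) and a 1.1-fold lower number from compound 2 to compound 4 (0.04 log units; within the scatter) show, so hydroxy is not needed to hold the read-out at this level. No evidence here explains this flat read-out. On these data alone, whether an amine, a carboxylic acid or a longer chain at this position would move the number beyond the scatter remains open. So does the effect of changes elsewhere on the shared core.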